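Formyl to Thiophene Enone: Estimating Compound 4

The source may hold more compounds than are shown below. What is called first, only, known or untested is meant among the compounds shown, and "the series" means these compounds.

Compound 1, `COc1ccc(-c2cc3ccccc3nc2C=O)cc1`: > 10000 nM
Compound 2, `COc1ccc(-c2cc3ccccc3nc2/C=C/C(=O)c2ccc(O)cc2)cc1`: 5690 nM
Compound 3, `COc1ccc(C(=O)/C=C/c2nc3ccccc3cc2-c2ccc(OC)cc2)cc1`: > 10000 nM

In a functional assay on H184B5F5/M10 cells (Homo sapiens) for antiproliferative activity, read by XTT assay, with a stated time of 72 h (on this read-out lower numbers stand for stronger inhibition and higher numbers for weaker inhibition), compound 1 reaches only a limit and no number, sitting at the limit of > 10000 nM in this assay, at which 2 of the 3 values shown sit. The unmeasured compound 4, `COc1ccc(-c2cc3ccccc3nc2/C=C/C(=O)c2ccsc2)cc1`, differs from compound 1 by 2-((thiophen-3-yl)carbonyl)ethenyl in place of formyl on an aromatic carbon. Among the measured compounds shown here, no measured step converts a formyl into such an enone, so only the pair of enones already measured gives guidance: compound 2 gives a number, whereas compound 3 is a limit, and an at least 1.7-fold higher number from compound 2 to compound 3 (0.24 log units; that floor lies within the scatter). Compound 4 carries no hydroxyl, so for it a weak result near the limit is expected, with a step that the limit leaves unreadable from compound 1 to compound 4. Compound 4 is therefore estimated at 12000 nM, within 4000 nM to 40000 nM, and a limit rather than a number is quite possible.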

Compound 4, half-maximal inhibitory concentration: 6390 nM
The estimate for compound 4 lay 1.9-fold (0.27 log units) above the measured number, and the stated range covers the measured number.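

Replacing formyl with the thiophene enone on this aromatic carbon gives a measurable value in this assay, and the step is an at least 1.5-fold lower number from compound 1 to compound 4 (0.19 log units; that floor lies within the scatter). Thiophen-3-yl on the carbonyl likewise gives an at least 1.5-fold lower number from compound 3 to compound 4 (0.19 log units; that floor lies within the scatter), while against 4-hydroxyphenyl it gives a 1.1-fold higher number from compound 2 to compound 4 (0.05 log units; within the scatter). An enone without a hydroxyl can therefore reach the level of compound 2, which compound 3 alone did not suggest.

From the compounds shown here alone, the true size of the first two steps stays open because compound 1 and compound 3 are limits: the limit of > 10000 nM in this assay, at which 2 of the 4 values shown sit. Whether an amine or a carboxylic acid on the ring at the carbonyl would lower the number also stays open.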